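This account rests on a few compounds, and the source may have more. Where it says the series, first, only, none or still open, it means among the compounds named here.

Measured so far:
Compound 1 `CCn1c(C(=O)NCCN(C)C)ccc1C(CC)(CC)c1ccc(OCCC(O)(CC)CC)c(C)c1`: in an assay on cells for agonist activity at vitamin D3 receptor (Homo sapiens), with a stated time of 96 h (on this read-out higher numbers stand for an effect only at larger amounts of compound and lower numbers for an effect already at smaller amounts), compound 1 gives 82 nM.
Compound 2 `CCn1c(C(=O)N(CCC#N)CCC#N)ccc1C(CC)(CC)c1ccc(OCCC(O)(CC)CC)c(C)c1`: in this assay compound 2 reaches only a limit of the assay, > 10000 nM.

Going by the values given here, compound 1 is the only compound with a numerical result on this read-out; the other value is a limit of the assay (the limit of > 10000 nM in this assay, at which 1 of the 2 values shown sits). Compound 3 `C=CCN(C)C(=O)c1ccc(C(CC)(CC)c2ccc(OCCC(O)(CC)CC)c(C)c2)n1CC` differs from compound 1 only at the group on the carbonyl carbon: allyl(methyl)amino in place of (2-(dimethylamino)ethyl)amino on a carbonyl carbon. Among the compounds with values here, one measured step bears on this position. Exchanging the same group in a different way gave an at least 120-fold higher number from compound 1 to compound 2 (2.08 log units; beyond the scatter), with compound 2 showing an effect only at the limit. That exchange put in a larger group; the change to compound 3 puts in a smaller one. Both replacements take away the (2-(dimethylamino)ethyl)amino group. Within the data shown here, on the single comparison available, a weaker effect is expected in this assay, with a step that may be large but remains uncertain because the one measured step, an at least 120-fold higher number from compound 1 to compound 2 (2.08 log units; beyond the scatter), ends at a limit. Compound 3 is therefore expected to give about 1000 nM, within 150 nM to 10000 nM. The expected step is a 12-fold higher number from compound 1 to compound 3 (1.09 log units; beyond the scatter).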

Compound 3, half-maximal effective concentration: > 10000 nM
Compound 3: no number, only a limit; the forecaster's own chance of this, stated with the estimate: 25%; middle value at least 10-fold (1.00 log units) away from the limit.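

In this assay, allyl(methyl)amino on the carbonyl carbon gives an at least 120-fold higher number from compound 1 to compound 3 (2.08 log units; beyond the scatter), so a smaller group here ends at the same loss of effect as the larger group in compound 2, and the result does not follow group size in one direction alone. Compound 2 and compound 3 each give only a limit and not a number, so the step between them cannot be read and neither can be ranked against the other: the limit of > 10000 nM in this assay, at which 2 of the 3 values shown sit. Among the three compounds, only compound 1 carries both the amide hydrogen and the dimethylamino group, and this link holds without exception in the compounds shown.

These compounds change the amide hydrogen and the dimethylamino group together, so they leave open which of the two matters, or whether both do. A simple methylamino group would keep the amide hydrogen without the dimethylamino group, methyl(2-(dimethylamino)ethyl)amino would do the reverse, and a longer chain such as (3-(dimethylamino)propyl)amino would ask how far the dimethylamino group can sit from the carbonyl carbon.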